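A few compounds are considered here, and "the series" means these few. Any claim that something is new, unique, unknown or untested is made for them only; others in the source may bear on it.

Measured so far:
- compound 1, `Cc1c(/N=C/c2cccc(O)c2)c(=O)n(-c2ccccc2)n1C`: 437000000 nM
- compound 2, `COc1cccc(/C=N/c2c(C)n(C)n(-c3ccccc3)c2=O)c1`: 105000000 nM

In a functional assay on P388 cells (Mus musculus) for cytotoxicity, read by MTT assay, with a stated time of 72 h (a lower number here means a stronger inhibitor, a higher number a weaker inhibitor), compound 2 gives the lower of the two numbers shown, with compound 1 the nearer neighbour at a higher number. Within the data shown here, the one change recorded, a 4.2-fold lower number from compound 1 to compound 2 (0.62 log units; beyond the scatter), shows that capping the ring hydroxyl as a methoxy group lowered the number by a modest amount, beyond the scatter.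

Compound 3, `COc1cc(/C=N/c2c(C)n(C)n(-c3ccccc3)c2=O)ccc1O`, keeps the methoxy group of compound 2 but adds (hydroxy in place of hydrogen on an aromatic carbon), ortho to a methoxy group and para to a large group. Among the measured compounds shown here, no measured pair tests exactly this change; the only related step is the one from compound 1 to compound 2, where a free hydroxyl on this ring went with a higher number. Restoring a free hydroxyl, though at a new place, is therefore expected to give a modest rise, a 1.9-fold higher number from compound 2 to compound 3 (0.28 log units; within the scatter), and compound 3 is estimated at 200000000 nM, between 60000000 nM and 600000000 nM.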

Compound 3, half-maximal inhibitory concentration: 316000000 nM
Estimate against measurement, compound 3: 1.6-fold (0.20 log units) below; measured number inside the range.
By their numbers in this assay, from the lowest: compound 2; then compounds 3 and 1 (each within the scatter of the next).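

In this assay, placing a hydroxy group on an aromatic carbon, ortho to a methoxy group and para to a large group, gives a 3.0-fold higher number from compound 2 to compound 3 (0.48 log units; beyond the scatter) and so moves the number beyond the scatter: this place on the ring is not indifferent to the change. With the earlier 4.2-fold lower number from compound 1 to compound 2 (0.62 log units; beyond the scatter) in view, the compound with the free hydroxy group carries the higher number in both measured pairs, and the two hydroxy groups stand at different places on the ring. Nothing available explains why the number rises here.

On these data alone, what an amine, a chlorine atom or a carboxylic acid at this place would do to the number remains open. Also open, as far as these compounds go, is whether a longer chain on the oxygen, such as ethoxy, would behave like the methoxy group.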